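Swapping an Aryl Ether for a Branched Alkyl Chain

This account rests on a few compounds, and the source may have more. Where it says the series, first, only, none or still open, it means among the compounds named here.

Compound 1 `COc1ccc(Oc2ccc3c(NCCCNCc4cc(F)ccc4OC)ccnc3c2)cc1` gives 7000 nM in an ADME assay on HepG2 cells (Homo sapiens) for cytotoxicity, read by luminescence, CellTiter-Glo and ATP content, with a stated time of 72 h; on this read-out lower numbers stand for an effect already at smaller amounts and higher numbers for an effect only at larger amounts of compound.
Compound 2 `Fc1ccc(-c2ccc3c(NCCCNCc4ccco4)ccnc3c2)cc1` gives 7760 nM in this assay.
Compound 3 `COc1ccc(Oc2ccc3c(NCCCNCc4cccc(OC)c4O)ccnc3c2)cc1` gives 5500 nM in this assay.

Compound 3 sits within the usual scatter of both compound 1 and compound 2, so the three measured compounds cannot be told apart on this read-out. Going by the values given here, the only single-point step measured so far, a 1.3-fold lower number from compound 1 to compound 3 (0.10 log units; within the scatter), changes the aryl group on the chain carbon bound to the amine nitrogen and stays within the scatter.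

Compound 4 `CCC(CC)c1ccc2c(NCCCNCc3cccc(OC)c3O)ccnc2c1` has not been measured. It differs from compound 3 at the core: pentan-3-yl in place of 4-methoxyphenoxy on an aromatic carbon. No measured step touches this position, so nothing shown here bears directly on it; the values of compound 1, compound 2 and compound 3 simply cluster together despite their differing groups. With no guidance toward a shift in either direction, compound 4 is expected to stay close to compound 3, a step of no change at the digits printed from compound 3 to compound 4 (within the scatter). The estimate for compound 4 in this assay is 5500 nM, with a range from 2000 nM to 15000 nM.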

Compound 4, half-maximal effective concentration: 410 nM
The estimate for compound 4 lay 13-fold (1.13 log units) above the measured number, outside the stated range (below it).
By their numbers in this assay, from the lowest: compound 4; then compounds 3, 1 and 2 (each within the scatter of the next).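

Going by these compounds alone, compound 3 and compound 4 show that this position on the shared core can matter a great deal in this assay, a point the earlier compounds could not show. Pentan-3-yl in place of 4-methoxyphenoxy gives a 13-fold lower number from compound 3 to compound 4 (1.13 log units; beyond the scatter), so the effect appears at much smaller amounts of compound, whereas the only earlier step, made on the other side of the molecule, stayed within the scatter. The swap removes the aromatic ring and both ether oxygens together, and no measurement given explains the size of this step.

As far as these compounds go, whether losing the ring or gaining the branched alkyl group drives the step stays open; a straight pentyl chain or a cyclopentyl ring on the same carbon would help separate the two. From the compounds shown here alone, it is also open whether pentan-3-yl acts the same way alongside the 5-fluoro-2-methoxyphenyl group of compound 1.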